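Swapping the Amide Substituent on a Thiourea Scaffold

A few compounds are considered here, and "the series" means these few. Any claim that something is new, unique, unknown or untested is made for them only; others in the source may bear on it.

Compound 1 `O=C(c1cc(Oc2cccc(NC(=S)Nc3ccc(Cl)c(C(F)(F)F)c3)c2)ccn1)N1CCCC1`: 12100 nM
Compound 2 `O=C(NCc1ccccc1)c1cc(Oc2cccc(NC(=S)Nc3ccc(OC(F)(F)F)cc3)c2)ccn1`: 6800 nM

Both compounds were tested in a functional assay on PC-3 cells (Homo sapiens) for cytotoxicity, read by MTT assay, with a stated time of 48 h; on this read-out lower numbers stand for stronger inhibition and higher numbers for weaker inhibition. Compound 2 gives the lower of the two numbers, yet the gap between compound 2 and compound 1 lies within the usual scatter of repeated measurements, so on these two values the pair cannot be told apart.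

Compound 3 `O=C(c1cc(Oc2cccc(NC(=S)Nc3ccc(OC(F)(F)F)cc3)c2)ccn1)N1CCCC1` has not yet been measured in this assay. It keeps the shared core of compound 2 and differs in one place: pyrrolidin-1-yl in place of benzylamino on a carbonyl carbon. For the measured compounds named here, the group that enters here is already present in compound 1, so the change is not new to the series, but no pair of measured compounds shows it on its own, and its effect is unknown. With nothing pointing strongly either way, the expected step from compound 2 to compound 3 in this assay is a 1.3-fold higher number from compound 2 to compound 3 (0.12 log units; within the scatter), a shift no larger than the scatter and, if anything, toward a somewhat higher number. Compound 3 is accordingly estimated at 9000 nM in this assay, with a likely range from 3000 nM to 27000 nM.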

Compound 3, half-maximal inhibitory concentration: 34100 nM
The estimate for compound 3 lay 3.8-fold (0.58 log units) below the measured number, and the stated range ends below it.
By their numbers in this assay, from the lowest: compounds 2 and 1 (each within the scatter of the next); then compound 3.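

In this assay, the group on the carbonyl carbon now has a measured effect of its own: with the rest of the molecule unchanged, pyrrolidin-1-yl in place of benzylamino gives a 5.0-fold higher number from compound 2 to compound 3 (0.70 log units; beyond the scatter) and so weaker inhibition, which shows that this position is sensitive to the change. The other end of the molecule matters too, since 4-(trifluoromethoxy)phenyl in place of 4-chloro-3-(trifluoromethyl)phenyl on an amide-type nitrogen, with pyrrolidin-1-yl kept in both compounds, gives a 2.8-fold higher number from compound 1 to compound 3 (0.45 log units; beyond the scatter) and again weakens inhibition. Nothing in the available data explains why either step occurs.

The benzylamino group differs from pyrrolidin-1-yl in its aromatic ring, its size and its hydrogen-bond donor, and these two steps cannot separate those differences, so a methylamino or a diethylamino group on the same carbonyl carbon would be informative. From the compounds shown here alone, it also remains open whether benzylamino combined with 4-chloro-3-(trifluoromethyl)phenyl would give a similar step, which would show whether the two changes act independently or depend on each other.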